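Methyl additions on the aryl-triazole and piperidine ends

The source may report more compounds than this note shows. Statements on the series, on what has been measured and on what is new or still open speak of the compounds shown alone.

Compound 1 `COc1cc2c(Oc3ccc(NC(=O)c4cn(-c5ccccc5C)nn4)cc3F)ccnc2cc1OCCCN1CCCCC1` is the reference of this small set; in a functional assay on HT-29 cells (Homo sapiens) for cytotoxicity, read by MTT assay, with a stated time of 72 h (a higher number here means a weaker inhibitor, a lower number a stronger inhibitor), compound 1 gives 1340 nM. Compound 2 `COc1cc2c(Oc3ccc(NC(=O)c4cn(-c5c(C)cccc5C)nn4)cc3F)ccnc2cc1OCCCN1CCCCC1` carries the change (methyl in place of hydrogen on an aromatic carbon), and in this assay compound 2 gives 3690 nM; the step of a 2.8-fold higher number from compound 1 to compound 2 (0.44 log units; beyond the scatter) is beyond the scatter. Compound 3 `COc1cc2c(Oc3ccc(NC(=O)c4cn(-c5ccccc5C)nn4)cc3F)ccnc2cc1OCCCN1CCC(C)CC1` differs from compound 1 at the other end of the molecule, by methyl in place of hydrogen on a saturated ring carbon, and in this assay compound 3 gives 2380 nM; the step of a 1.8-fold higher number from compound 1 to compound 3 (0.25 log units; within the scatter) stays within the scatter, so compound 1 and compound 3 cannot be ordered on these numbers.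

Compound 4 `COc1cc2c(Oc3ccc(NC(=O)c4cn(-c5c(C)cccc5C)nn4)cc3F)ccnc2cc1OCCCN1CCC(C)CC1` has not yet been measured. It differs from compound 3 by methyl in place of hydrogen on an aromatic carbon, which is the same change made from compound 1 to compound 2; the two places read alike word for word, and the cores of compound 3 and compound 4 differ from those of compound 1 and compound 2 only by methyl in place of hydrogen on a saturated ring carbon. In the absence of any further pairing, the expectation is that this change will behave as it did once already: the step from compound 3 to compound 4 is expected to be a 2.7-fold higher number from compound 3 to compound 4 (0.44 log units; beyond the scatter), resting on the earlier 2.8-fold higher number from compound 1 to compound 2 (0.44 log units; beyond the scatter). Accordingly, compound 4 is expected to give about 6500 nM in this assay, with a range from 3000 nM to 14000 nM allowing for scatter in the assay and for the single precedent.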

Compound 4, half-maximal inhibitory concentration: 2450 nM
Compound 4: the middle estimate sits 2.7-fold (0.42 log units) above what was measured; the measured number lies below the stated range.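

In this assay, the 2-methylphenyl to 2,6-dimethylphenyl change gives a 1.0-fold higher number from compound 3 to compound 4 (0.01 log units; within the scatter), so the step seen on the core of compound 1 does not carry over to the core of compound 3: the same change on two cores in this assay, a 2.8-fold higher number (0.44 log units; beyond the scatter) from compound 1 to compound 2 and a 1.0-fold higher number (0.01 log units; within the scatter) from compound 3 to compound 4, 2.7-fold (0.43 log units) apart, beyond the scatter of two such steps

The methyl on the saturated ring also depends on its partner, giving a 1.5-fold lower number from compound 2 to compound 4 (0.18 log units; within the scatter), and this step does not match its earlier counterpart: the same change on two cores in this assay, a 1.8-fold higher number (0.25 log units; within the scatter) from compound 1 to compound 3 and a 1.5-fold lower number (0.18 log units; within the scatter) from compound 2 to compound 4, 2.7-fold (0.43 log units) apart, beyond the scatter of two such steps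

The two methyl changes therefore cannot be treated as independent increments in these four compounds, but the result rests on one pair of steps for each change and does not show why the steps differ or whether the same dependence would appear on any other core.

Still open, going by these compounds, is whether an ethyl or methoxy group in place of the added aromatic methyl would depend on the piperidine end in the same way. A hydroxyl group in place of the methyl on the saturated ring leaves the same question open from the other end of the molecule.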